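Hepatic extraction across a short aryl series

A few compounds are considered here, and "the series" means these few. Any claim that something is new, unique, unknown or untested is made for them only; others in the source may bear on it.

Measured so far:
compound 1, `COc1ccc(-n2cnc3cnc(-c4cccc(NC(C)=O)c4)cc32)cc1OC`: 0.21
compound 2, `COc1ccc(-n2cnc3cnc(-c4ccccc4)cc32)cc1OC`: 1

In an ADME assay on S9 fraction from liver (Mus musculus) for metabolic stability, read by LC-MS, using NADPH, with a stated time of 45 min, tested at 3 uM, in the presence of a further agent that is not named here (on this read-out higher numbers stand for higher hepatic extraction and lower numbers for lower hepatic extraction), compound 2 gives 1, the highest of the two numbers recorded; compound 1 sits below it, and the step a number 0.79 higher from compound 1 to compound 2 (beyond the scatter) was hydrogen in place of acetamido on an aromatic carbon, a large shift beyond the scatter.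

Compound 3, `COc1ccc(-n2cnc3cnc(-c4ccc(F)cc4OC)cc32)cc1OC`, remains unmeasured. Its change from compound 2 is 4-fluoro-2-methoxyphenyl in place of phenyl on an aromatic carbon. For the measured compounds named here, no measured step alters the phenyl on this position of the shared core, so the only step available, a number 0.79 higher from compound 1 to compound 2 (beyond the scatter), concerns a different site and bears on compound 3 only loosely. Compound 2 already stands at the top of the scale, so any move in this assay for compound 3 can only be downward or none beyond the scatter; a modest drop, a number 0.15 lower from compound 2 to compound 3 (beyond the scatter), is expected. The estimate for compound 3 is 0.85, within 0.6 to 1.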

Compound 3, hepatic extraction ratio: 1
The estimate for compound 3 lay 0.15 below the measured number; low and high end bracket the measured number.
By their numbers in this assay, from the lowest: compound 1; then compounds 2 and 3 (each within the scatter of the next).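

In this assay the step at this position reads no change at the digits printed from compound 2 to compound 3 (within the scatter), so 4-fluoro-2-methoxyphenyl and phenyl cannot be told apart on this aromatic carbon next to the ring nitrogen. The earlier compounds shown here showed only the loss of acetamido from this aryl group; this result adds that fluoro and methoxy together on the ring leave the read-out where phenyl puts it, unlike the step a number 0.79 higher from compound 1 to compound 2 (beyond the scatter). No measurement at hand accounts for either outcome.

Still open, going by these compounds, is whether fluoro or methoxy alone on this ring would give the same reading as the pair. On these data alone, it is also open whether an amine or a carboxylic acid on this ring would give a step of the size seen with acetamido, or none.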